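This account rests on a few compounds, and the source may have more. Where it says the series, first, only, none or still open, it means among the compounds named here.

Measured so far in an assay on HEK293 cells for agonist activity at transient receptor potential cation channel subfamily M member 8 (Homo sapiens), read by fluorescence and calcium flux, with a stated time of 15 min; a lower number here means that less compound is needed, a higher number that more compound is needed for the effect:
compound 1 `CCN(Cc1cccs1)C(=O)COc1ccc(C)cc1` gives 8 nM;
compound 2 `Cc1ccc(OCC(=O)N(Cc2cccs2)c2ccncc2)cc1` gives 52 nM.

Among these two numbers, compound 2 stands highest; its nearest neighbour is compound 1, and the step of a 6.5-fold higher number from compound 1 to compound 2 (0.81 log units; beyond the scatter) lies beyond the scatter, so compound 2 needs more compound than compound 1 for the same effect. Compound 3 `Cc1ccc(OCC(=O)N(Cc2cccs2)c2c(C)n[nH]c2C)cc1` differs from compound 2 in one place: 3,5-dimethyl-1H-pyrazol-4-yl in place of pyridin-4-yl on an amide-type nitrogen. Within the data shown here, the only measured step, a 6.5-fold higher number from compound 1 to compound 2 (0.81 log units; beyond the scatter), swaps a short chain for a six-membered aromatic ring on that nitrogen; it does not compare one aromatic ring with another, so it bears only loosely on this change. With an aromatic ring kept on the amide-type nitrogen, the expectation for compound 3 is a number near that of compound 2, and the estimated step of a 1.5-fold higher number from compound 2 to compound 3 (0.19 log units; within the scatter) is expected to stay within or just beyond the scatter. Compound 3 is therefore estimated at 80 nM, with a range from 20 nM to 400 nM.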

Compound 3, half-maximal effective concentration: 0.3 nM
Beside the measured number, compound 3's estimate is 270-fold (2.43 log units) above it; measured number below the stated range.
By their numbers in this assay, from the lowest: compound 3; then compound 1; then compound 2.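

In this assay, the amide-type nitrogen proves far more sensitive to which aromatic ring it carries than the earlier pair could show: exchanging pyridin-4-yl for 3,5-dimethyl-1H-pyrazol-4-yl gives a 170-fold lower number from compound 2 to compound 3 (2.24 log units; beyond the scatter) in a single change. An aromatic ring at this place therefore does not always raise the number, as compound 2 alone might have suggested, and this group also compares favourably with ethyl, with a 27-fold lower number from compound 1 to compound 3 (1.43 log units; beyond the scatter) at the same nitrogen. Nothing available explains why this change has so large an effect.

The compounds shown do not separate the part played by the five-membered ring from that of its two methyl groups or the hydrogen on its ring nitrogen. On these data alone, an unsubstituted 1H-pyrazol-4-yl and a 1,3,5-trimethyl-1H-pyrazol-4-yl group would be the closest comparisons, and both remain open here.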